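This account rests on a few compounds, and the source may have more. Where it says the series, first, only, none or still open, it means among the compounds named here.

Measured compounds in a functional assay on BGC-823 cells (Homo sapiens) for inhibition, read by MTT assay, with a stated time of 72 h; on this read-out lower numbers stand for stronger inhibition and higher numbers for weaker inhibition:
Compound 1 `Cc1cc(N2CC[C@@H](C)[C@@H](N(C)c3ncnc4[nH]ccc34)C2)n2nc(SCc3cc(Cl)ccc3Cl)nc2n1` gives 18900 nM.
Compound 2 `Cc1cc(N2CC[C@@H](C)[C@@H](N(C)c3ncnc4[nH]ccc34)C2)n2nc(SCc3ccc(Cl)cc3)nc2n1` gives 26300 nM.
Compound 3 `Cc1cc(N2CC[C@@H](C)[C@@H](N(C)c3ncnc4[nH]ccc34)C2)n2nc(SCc3nc4ccccc4[nH]3)nc2n1` reaches only a limit, > 100000 nM, not a number.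

Compound 3 thus sits at the weak end of the series, its value being a limit (the limit of > 100000 nM in this assay, at which 1 of the 3 values shown sits). Compound 4 `Cc1cc(N2CC[C@@H](C)[C@@H](N(C)c3ncnc4[nH]ccc34)C2)n2nc(SCCCc3ccccc3)nc2n1` differs from it by phenethyl in place of 1H-benzimidazol-2-yl on a saturated chain carbon bound to a sulfur. The measured steps that bear on this change run in the opposite direction: an at least 5.2-fold higher number from compound 1 to compound 3 (0.72 log units; beyond the scatter) and an at least 3.8-fold higher number from compound 2 to compound 3 (0.58 log units; beyond the scatter). Both show the 1H-benzimidazol-2-yl on a saturated chain carbon bound to a sulfur giving a higher number than either chlorophenyl variant, while a 1.4-fold higher number from compound 1 to compound 2 (0.14 log units; within the scatter) between the two chlorophenyl compounds was small. Compound 4, carrying a six-membered aromatic ring of carbon only as 3-phenylpropyl, is expected to move back toward the chlorophenyl pair, a step estimated as an at least 3.3-fold lower number from compound 3 to compound 4 (0.52 log units; beyond the scatter). Compound 4 is estimated at 30000 nM, between 10000 nM and 100000 nM.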

Compound 4, half-maximal inhibitory concentration: > 100000 nM
Compound 4: a limit, no number (the forecaster's own chance of this, stated with the estimate: 30%); middle value at least 3.3-fold (0.52 log units) away from the limit.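

In this assay compound 4 gives > 100000 nM, a limit and not a number, so the step from compound 3 cannot be read: the limit of > 100000 nM in this assay, at which 2 of the 4 values shown sit.

A six-membered aromatic ring of carbon only does not by itself hold the activity of the chlorophenyl compounds at this position, with an at least 3.8-fold higher number from compound 2 to compound 4 (0.58 log units; beyond the scatter) and an at least 5.2-fold higher number from compound 1 to compound 4 (0.72 log units; beyond the scatter). Compound 4 thus joins compound 3 at the limit, although the benzimidazole donor and acceptor are gone.

From the compounds shown here alone, whether these higher numbers follow the longer chain or the missing chlorine stays open. An unsubstituted benzyl in place of 3-phenylpropyl would separate the two, and an amine there remains untested in the compounds shown.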